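A few compounds are considered here, and "the series" means these few. Any claim that something is new, unique, unknown or untested is made for them only; others in the source may bear on it.

Of the compounds shown here, three have been tested in an assay on isolated protein for inhibition of DNA topoisomerase 1 (Homo sapiens), with a stated time of 30 min, tested at 100 uM (a lower number here means a weaker effect, a higher number a stronger effect of the compound at the concentration tested), all built on a shared core that carries a hydroxyphenyl group, a chlorophenyl group and a third ring. Compound 1, with the structure `Oc1cccc(-c2cc(-c3cccnc3)nc(-c3cccc(Cl)c3)c2)c1`, gives 27.6% in this assay. Compound 2, with the structure `Oc1cccc(-c2cc(-c3ccsc3)nc(-c3cccc(Cl)c3)c2)c1`, gives 26.2%. Compound 3, with the structure `Oc1ccc(-c2cc(-c3ccsc3)nc(-c3ccccc3Cl)c2)cc1`, gives 4.1%, the lowest of the three, and its distance to both compound 1 and compound 2 lies beyond the scatter. The difference between the core of compound 3 and the core of compound 2 is not broken down here; the two hold the same atoms joined differently.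

Compound 1 and compound 2 differ in one place: pyridin-3-yl in place of thiophen-3-yl on an aromatic carbon. In this assay that change gave a number 1.4 percentage points higher from compound 2 to compound 1 (within the scatter), so the pyridin-3-yl and the thiophen-3-yl ring behaved alike there.

Compound 4, with the structure `Oc1ccc(-c2cc(-c3cccnc3)nc(-c3ccccc3Cl)c2)cc1`, has not yet been measured. It arises from compound 3 by the same kind of change: pyridin-3-yl in place of thiophen-3-yl on an aromatic carbon. The surroundings are not the same, since here the place is meta to a 2-chlorophenyl group and meta to a 4-hydroxyphenyl group, whereas in the earlier pair it was meta to a 3-chlorophenyl group and meta to a 3-hydroxyphenyl group.

Because a number 1.4 percentage points higher from compound 2 to compound 1 (within the scatter) stayed within the scatter, a similarly small step is expected, namely a number 1.9 percentage points higher from compound 3 to compound 4 (within the scatter). Compound 4 is therefore estimated to give 6% in this assay, most likely between 0% and 18%.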

Compound 4, a percentage reported as inhibition, at one concentration (the size of the read-out at that concentration, not a potency): 0.9%
The estimate for compound 4 lay 5.1 percentage points above the measured number, within the range that was stated.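

In this assay, putting pyridin-3-yl in place of thiophen-3-yl on the core of compound 3 gave a number 3.2 percentage points lower from compound 3 to compound 4 (within the scatter), so on this core too the two rings cannot be told apart. The change therefore reads the same on both cores: the same change on two cores in this assay, a number 1.4 percentage points higher (within the scatter) from compound 2 to compound 1 and a number 3.2 percentage points lower (within the scatter) from compound 3 to compound 4, 4.6 percentage points apart, within the scatter of two such steps. Going by these compounds alone, this shows only that the exchange of these two rings carried over between two cores without a step beyond the scatter; it does not show that the rings are interchangeable on other cores or at other concentrations, and with compound 3 at 4.1% and compound 4 at 0.9%, the second pair sits so close to zero that it had little room to show a drop.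

Open, as far as these compounds go, is whether a different group in that place, such as a plain phenyl ring, an amine or a carboxylic acid, would move the read-out beyond the scatter on either core. Also open is what separates the two cores themselves, as no pair shown changes only the chlorophenyl group or only the hydroxyphenyl group.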